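The compounds below may be only part of what the source reports. "The series", "measured", "known", "first", "only" and "open" are said of these compounds alone.

Working notes on the series.

Activity is followed in a functional assay on A549 cells (Homo sapiens) for antiproliferative activity, read by MTT assay, with a stated time of 72 h; on this read-out higher numbers stand for weaker inhibition and lower numbers for stronger inhibition. Compound 1 `O=C1COc2ccc(-c3cccc(NS(=O)(=O)c4ccc(F)cc4)c3)cc2N1c1ccc(Cl)cc1` gives 31600 nM in this assay. Compound 2 `O=C1COc2ccc(-c3cccc(NS(=O)(=O)c4ccc(F)cc4)c3)cc2N1c1ccccc1` is the same core with a hydrogen in place of chloro on an aromatic carbon, the change read as hydrogen in place of chloro on an aromatic carbon. For compound 2 the value > 40000 nM is a limit of the assay and not a number. The step of an at least 1.2-fold higher number from compound 1 to compound 2 (0.10 log units; that floor lies within the scatter) is therefore only a floor, set because of the limit of > 40000 nM in this assay, at which 1 of the 3 values shown sits.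

Compound 3 `O=C1COc2ccc(-c3cnc(Cl)c(NS(=O)(=O)c4ccc(F)cc4)c3)cc2N1c1ccc(Cl)cc1` gives 21600 nM in this assay. The difference between its core and the core of compound 1 is not broken down here. Its value and that of compound 1 lie within the usual scatter of each other, so no ordering is drawn from them.

Compound 4 `O=C1COc2ccc(-c3cnc(Cl)c(NS(=O)(=O)c4ccc(F)cc4)c3)cc2N1c1ccccc1` differs from compound 3 by hydrogen in place of chloro on an aromatic carbon; the place of the change is the same, word for word, as in the change from compound 1 to compound 2, so this is the same change made on a second core. Within the data shown here, the one measured instance of it gave no number beyond its floor. On that basis the expected step is a 1.4-fold higher number from compound 3 to compound 4 (0.14 log units; within the scatter), a small loss that may run into the assay limit, as it did for compound 2. For compound 4 in this assay the expected value is 30000 nM, with a range from 15000 nM to 60000 nM.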

Compound 4, half-maximal inhibitory concentration: 14700 nM
Beside the measured number, compound 4's estimate is 2.0-fold (0.31 log units) above it, outside the stated range (below it).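

Replacing 4-chlorophenyl by phenyl on the second core gives, in this assay, a 1.5-fold lower number from compound 3 to compound 4 (0.17 log units; within the scatter), a step inside the usual scatter, so no ordering of the two compounds follows from it. Set beside the same change on the first core, the result reads: the same change on two cores in this assay, an at least 1.2-fold higher number (0.10 log units; that floor lies within the scatter) from compound 1 to compound 2 and a 1.5-fold lower number (0.17 log units; within the scatter) from compound 3 to compound 4; the limit leaves it open whether they differ. One step inside the scatter and one known only as a floor do not show that the change carries over from core to core, nor do they show that its outcome depends on the core, and the first of the two steps cannot be sized further: the limit of > 40000 nM in this assay, at which 1 of the 4 values shown sits.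

The compounds shown leave open whether any other group at the place held by chloro, such as a fluoro, a methoxy, an amine or a carboxylic acid, would give a step beyond the scatter on either core. They also leave open whether a longer chain at that place would do so, and whether hydrogen in place of chloro would read the same way on a third core, where a second pair with two numbers could settle the comparison.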